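A few compounds are considered here, and "the series" means these few. Any claim that something is new, unique, unknown or untested is made for them only; others in the source may bear on it.

Of the compounds shown here, three built on a shared core have been tested in an ADME assay on HeLa cells (Homo sapiens) for cytotoxicity, read by cell counting, with a stated time of 4 days; a higher number here means a weaker inhibitor, a lower number a stronger inhibitor. Compound 1 `CC(C)c1ccc(-n2cc(-c3cn([C@H]4C[C@H](O)[C@@H](CO)O4)c(=O)[nH]c3=O)nn2)cc1` gives 6200 nM there. Compound 2 `O=c1[nH]c(=O)n([C@H]2C[C@H](O)[C@@H](CO)O2)cc1-c1cn(-c2ccc(Br)cc2)nn1` gives 1370 nM in this assay. Compound 2 differs from compound 1 in a single place, (bromo in place of isopropyl on an aromatic carbon), and that change brought a 4.5-fold lower number from compound 1 to compound 2 (0.66 log units; beyond the scatter). Compound 3 `CC(C)c1ccc(-n2nncc2-c2cn([C@H]3C[C@H](O)[C@@H](CO)O3)c(=O)[nH]c2=O)cc1` holds the same atoms as compound 1, joined in a different way; the difference between the two cores is not broken down here. For compound 3 this assay reports only a limit, > 200000 nM. Among the compounds with values here, compound 4 `O=c1[nH]c(=O)n([C@H]2C[C@H](O)[C@@H](CO)O2)cc1-c1cnnn1-c1ccc(Br)cc1` has not yet been measured; it differs from compound 3 by bromo in place of isopropyl on an aromatic carbon, the same change as the one between compound 1 and compound 2, at the same kind of place. Because this change once gave a 4.5-fold lower number from compound 1 to compound 2 (0.66 log units; beyond the scatter), compound 4 is expected to show an at least 2.0-fold lower number from compound 3 to compound 4 (0.30 log units; that floor lies within the scatter). Since the starting value of compound 3 is only a limit, the result for compound 4 may again be a limit rather than a number. Compound 4 is expected to fall near 100000 nM, within a range from 30000 nM to 400000 nM.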

Compound 4, half-maximal inhibitory concentration: 8000 nM
Compound 4: middle estimate off by 13-fold (1.10 log units), on the high side; measured number below the stated range.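

Replacing isopropyl with bromo gives the lower number, and so the stronger inhibitor, in this assay on both cores, and on the core of compound 3 the change brings an at least 25-fold lower number from compound 3 to compound 4 (1.39 log units; beyond the scatter). The direction therefore carries over from one core to the other, but the size does not, so a step measured on one core is a poor guide to its size on the other: the same change on two cores in this assay, a 4.5-fold lower number (0.66 log units; beyond the scatter) from compound 1 to compound 2 and an at least 25-fold lower number (1.39 log units; beyond the scatter) from compound 3 to compound 4, at least 5.5-fold (0.74 log units) apart, beyond the scatter of two such steps. Compound 3 has only a limit, > 200000 nM, so the true size of its step is not known, and two cores cannot establish a rule for the series: the limit of > 200000 nM in this assay, at which 1 of the 4 values shown sits.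

The compounds shown carry only isopropyl or bromo at this place on the aromatic ring, so it remains open whether a chloro group, a methoxy group or an amine there would also separate the two cores so widely. These values also do not tell why the same change differs in size between the two cores.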